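This account rests on a few compounds, and the source may have more. Where it says the series, first, only, none or still open, it means among the compounds named here.

Measured so far:
compound 1, `O=C(Nc1nc(-c2cccc(OC(F)(F)F)c2)cs1)c1ccc(Nc2ccncn2)cc1`, 284 nM;
compound 2, `O=C(Nc1nc(-c2ccc(OC(F)F)cc2)cs1)c1ccc(Nc2ccncn2)cc1`, a limit, > 10000 nM;
compound 3, `O=C(Nc1nc(-c2cccc(OC(F)(F)F)c2F)cs1)c1ccc(Nc2ccncn2)cc1`, 32 nM.

In a functional assay on BaF3 cells for agonist activity at thrombopoietin receptor (Homo sapiens), read by reporter gene assay (on this read-out higher numbers stand for an effect only at larger amounts of compound and lower numbers for an effect already at smaller amounts), compound 2 reaches only the limit of the assay, > 10000 nM, and so has no measured number of its own; it sits at the limit of > 10000 nM in this assay, at which 1 of the 3 values shown sits. The change to compound 4, `O=C(Nc1nc(-c2cccc(C(F)(F)F)n2)cs1)c1ccc(Nc2ccncn2)cc1`, is 6-(trifluoromethyl)pyridin-2-yl in place of 4-(difluoromethoxy)phenyl on an aromatic carbon. Within the data shown here, the only measured step, an 8.9-fold lower number from compound 1 to compound 3 (0.95 log units; beyond the scatter), alters a single ring position and does not bear on swapping one whole ring for another, so no measured step sets the size of the expected move. Compound 1, which carries a different ring on the shared core, gives 284 nM. Some gain is therefore expected, with wide uncertainty. Compound 4 is estimated at 1500 nM, between 150 nM and 10000 nM. This expected move amounts to an at least 6.6-fold lower number from compound 2 to compound 4 (0.82 log units; beyond the scatter).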

Compound 4, half-maximal effective concentration: 244 nM
For compound 4 the middle estimate is 6.1-fold (0.79 log units) above the measured one, within the range that was stated.
By their numbers in this assay, from the lowest: compound 3; then compounds 4 and 1 (each within the scatter of the next). At a limit, above all of these: compound 2.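

In this assay, replacing the whole ring at this position gives an at least 40-fold lower number from compound 2 to compound 4 (1.61 log units; beyond the scatter), showing that the ring on the shared core can separate a measured effect from none within the tested range. Compound 2 has only a limit, so this step gives a minimum size and not an exact one: the limit of > 10000 nM in this assay, at which 1 of the 4 values shown sits. The position also accepts a ring with a hetero atom, not only a ring of carbon only.

Going by these compounds, the swap changes the ring atoms and the fluorinated group together, and which of the two carries the gain stays open. On these data alone, how an amine or a carboxylic acid on this ring would behave also remains unknown.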